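Fluoromethyl for hydroxymethyl in a cytotoxicity series

A few compounds are considered here, and "the series" means these few. Any claim that something is new, unique, unknown or untested is made for them only; others in the source may bear on it.

Compound 1, `COc1cc(C(c2ccc(O)c(OC)c2)[C@H](CO)C(C)C)ccc1O`, in a functional assay on HeLa cells (Homo sapiens) for cytotoxicity, read by WST assay, with a stated time of 48 h; a higher number here means a weaker inhibitor, a lower number a stronger inhibitor: > 100000 nM, a limit of the assay.
Compound 2, `COc1cc(C(c2ccc(O)c(OC)c2)[C@H](C)[C@@H](C)CO)ccc1O`, in this assay: > 100000 nM, a limit of the assay.

Within the data shown here, compound 2 stands only at a limit, as does the one other value shown (the limit of > 100000 nM in this assay, at which 2 of the 2 values shown sit). Among the measured compounds shown here, the single measured step, a step that the two limits leave unreadable from compound 1 to compound 2, is therefore unreadable. Compound 3, `COc1cc(C(c2ccc(O)c(OC)c2)[C@H](CF)C(C)C)ccc1O`, differs from compound 2 in one place: 1-(fluoromethyl)-2-methylpropyl in place of 2-(hydroxymethyl)-1-methylpropyl on a saturated chain carbon bound to two aromatic carbons. For the measured compounds named here, no measured step bears on this change, so no direction can be drawn from it. The expected step is a number no higher from compound 2 to compound 3 (the limit leaves the size open), none beyond the scatter. Compound 3 is estimated at 100000 nM, between 30000 nM and 300000 nM.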

Compound 3, half-maximal inhibitory concentration: 19000 nM
Compound 3: middle estimate off by 5.3-fold (0.72 log units), on the high side; measured number below the stated range.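

Among these compounds, replacing hydroxy with fluoro on this chain gives the first number that falls within the range of this assay, with an at least 5.2-fold lower number from compound 1 to compound 3 (0.72 log units; beyond the scatter). The change of whole side chain gives an at least 5.2-fold lower number from compound 2 to compound 3 (0.72 log units; beyond the scatter). Both sizes remain open-ended because compounds 1 and 2 give only limits: the limit of > 100000 nM in this assay, at which 2 of the 3 values shown sit.

The compounds shown do not establish whether losing the hydroxy or gaining the fluorine drives this step. Nor do they show how an amine or a chlorine at the same chain carbon would compare with compound 3.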